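From 2,4-dichlorophenyl to 2-chloro-6-fluorophenyl

The source may hold more compounds than are shown below. What is called first, only, known or untested is meant among the compounds shown, and "the series" means these compounds.

Compound 1 `CN(C)Cc1cc(C(=O)/C=C/c2ccc(Cl)cc2Cl)cc(CN(C)C)c1O` gives 3090 nM
Compound 2 `CN(C)Cc1cc(C(=O)/C=C/c2ccc(Cl)c(Cl)c2)cc(CN(C)C)c1O` gives 2350 nM

Among the compounds with values here, in a functional assay on cells (Tumor Cell line, Homo sapiens) for cytotoxicity (on this read-out higher numbers stand for weaker inhibition and lower numbers for stronger inhibition), compound 1 lies within the scatter of compound 2, the only other compound measured so far. Compound 3 `CN(C)Cc1cc(C(=O)/C=C/c2c(F)cccc2Cl)cc(CN(C)C)c1O` is still unmeasured and differs from compound 1 as follows: 2-chloro-6-fluorophenyl in place of 2,4-dichlorophenyl on a double-bonded chain carbon bound to a double-bonded chain carbon. Within the data shown here, the one measured step that bears on this change, a 1.3-fold lower number from compound 1 to compound 2 (0.12 log units; within the scatter), stays within the scatter. Among the measured compounds shown here, no measured compound carries the 2-chloro-6-fluorophenyl group, so this evidence is thin. No step beyond the scatter is expected, and the estimated step is a 1.0-fold lower number from compound 1 to compound 3 (0.01 log units; within the scatter). Compound 3 is expected at 3000 nM, with an estimated range of 1300 nM to 6500 nM.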

Compound 3, half-maximal inhibitory concentration: 9120 nM
Beside the measured number, compound 3's estimate is 3.0-fold (0.48 log units) below it; measured number above the stated range.
By their numbers in this assay, from the lowest: compounds 2 and 1 (each within the scatter of the next); then compound 3.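

In this assay, this place on a double-bonded chain carbon proves sensitive to the aryl group after all. The two dichlorophenyl groups had stayed within the scatter of each other, yet 2-chloro-6-fluorophenyl gives a 3.0-fold higher number from compound 1 to compound 3 (0.47 log units; beyond the scatter) and, against the other dichlorophenyl group, a 3.9-fold higher number from compound 2 to compound 3 (0.59 log units; beyond the scatter). Both steps lie beyond the scatter and point to weaker inhibition, though no supporting measurement explains the change. Going by these compounds, it remains open which part of the 2-chloro-6-fluorophenyl group carries the shift, and where a plain phenyl or a methoxyphenyl group would fall at this place.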